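The compounds below may be only part of what the source reports. "The series", "measured", "known", "first", "only" and "open" are said of these compounds alone.

Measured so far:
compound 1, `COc1ncc(-c2ccc3nc(NC(=O)NC4CC4)sc3c2)cc1NS(=O)(=O)c1ccc(F)cc1`: 1190 nM
compound 2, `COc1ncc(-c2ccc3nc(NC(=O)NCCN(C)C)sc3c2)cc1NS(=O)(=O)c1ccc(F)cc1`: 500 nM
compound 3, `CCOC(=O)CNc1nc2ccc(-c3cnc(OC)c(NS(=O)(=O)c4ccc(F)cc4)c3)cc2s1`: "not determined" (no result reported)

In a functional assay on MCF7 cells (Homo sapiens) for antiproliferative activity, read by MTT assay, with a stated time of 72 h (on this read-out higher numbers stand for weaker inhibition and lower numbers for stronger inhibition), compound 1 gives 1190 nM, the highest of the two numbers available. Among the compounds with values here, the nearest entry is compound 2, with 500 nM; the change a 2.4-fold lower number from compound 1 to compound 2 (0.38 log units; beyond the scatter) is the only measured step, and it concerns a 2-(dimethylamino)ethyl group replacing cyclopropyl on an amide-type nitrogen, well away from the ring that is altered below. Compound 3 carries no number in this assay and adds nothing to the comparison.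

The compound now to be considered is compound 4, `O=C(Nc1nc2ccc(-c3cnc(Cl)c(NS(=O)(=O)c4ccc(F)cc4)c3)cc2s1)NC1CC1`. It differs from compound 1 as follows: chloro in place of methoxy on an aromatic carbon. The shared core, the urea with its cyclopropyl group and the ((4-fluorophenyl)sulfonyl)amino group are all retained; only the methoxy gives way to chloro on the aromatic carbon next to the ring nitrogen.

Within the data shown here, no measured step touches this position, so nothing here supports a prediction of movement in either direction beyond the scatter. The working expectation is therefore that compound 4 stays close to compound 1, with the estimated step of a 1.0-fold higher number from compound 1 to compound 4 (0.00 log units; within the scatter). Compound 4 is estimated at 1200 nM in this assay, in the range 400 nM to 3600 nM.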

Compound 4, half-maximal inhibitory concentration: 1090 nM
Compound 4: the middle estimate sits 1.1-fold (0.04 log units) above what was measured, within the range that was stated.
By their numbers in this assay, from the lowest: compound 2; then compounds 4 and 1 (each within the scatter of the next).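

In this assay, within the data shown here, chloro in place of methoxy on the aromatic carbon next to the ring nitrogen gives a 1.1-fold lower number from compound 1 to compound 4 (0.04 log units; within the scatter), the first measured step at this position, as the only earlier step lies on the urea side of the molecule. Compound 1 and compound 4 cannot be separated on this read-out, so at this carbon, ortho to the ((4-fluorophenyl)sulfonyl)amino group, neither the methoxy oxygen, counted as a hydrogen-bond acceptor, nor the methoxy carbon is needed to hold the number at this level. No measured property of these compounds bears on this result.

Going by these compounds, whether an amine, an ethoxy group or a bare hydrogen on this carbon would also leave the number in place remains open, since a single exchange cannot show how far this tolerance extends. Also open, on these data alone, is whether chloro at this position, combined with the 2-(dimethylamino)ethyl group on the urea, would keep the change seen in a 2.4-fold lower number from compound 1 to compound 2 (0.38 log units; beyond the scatter), which has so far been read only with methoxy present.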